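Dimethylamino for Difluoromethoxy: Three Measured Analogues, One Expected

A few compounds are considered here, and "the series" means these few. Any claim that something is new, unique, unknown or untested is made for them only; others in the source may bear on it.

Three compounds built on a shared core were tested in a functional assay on MCF-10A cells (Homo sapiens) for antiproliferative activity, with a stated time of 48 h; on this read-out lower numbers stand for an effect already at smaller amounts and higher numbers for an effect only at larger amounts of compound. Compound 1 `COc1ccc2nc(C)cc(NCc3ccc(OC(F)F)cc3)c2c1` gives 14700 nM, compound 2 `COc1ccc2nc(C)cc(NCc3cccc(OC(F)F)c3)c2c1` gives 14300 nM, and compound 3 `COc1ccc2nc(C)cc(NCc3ccc(N(C)C)cc3)c2c1` gives 20000 nM; all three numbers lie within the scatter of one another. Compound 2 holds the same atoms as compound 1 joined differently, and the difference between the two cores is not broken down here. Compound 3 arises from compound 1 by dimethylamino in place of difluoromethoxy on an aromatic carbon, and this change made a 1.4-fold higher number from compound 1 to compound 3 (0.13 log units; within the scatter). The unmeasured compound 4 `COc1ccc2nc(C)cc(NCc3cccc(N(C)C)c3)c2c1` arises from compound 2 by dimethylamino in place of difluoromethoxy on an aromatic carbon. The two changes are of the same kind but not the same: in compound 3 the entering group sits para to a large group, whereas in compound 4 it sits meta to a large group. Because the earlier step of a 1.4-fold higher number from compound 1 to compound 3 (0.13 log units; within the scatter) stayed within the scatter, compound 4 is expected to show a step of a 1.4-fold higher number from compound 2 to compound 4 (0.13 log units; within the scatter) in this assay. Compound 4 is therefore estimated at 19500 nM, with a range from 9000 nM to 42000 nM.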

Compound 4, half-maximal effective concentration: 14000 nM
For compound 4 the middle estimate is 1.4-fold (0.14 log units) above the measured one, within the range that was stated.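

In this assay, dimethylamino in place of difluoromethoxy on an aromatic carbon, meta to a large group, gave a 1.0-fold lower number from compound 2 to compound 4 (0.01 log units; within the scatter). Set beside the same change on the core of compound 1, the two steps do not differ: the same change on two cores in this assay, a 1.4-fold higher number (0.13 log units; within the scatter) from compound 1 to compound 3 and a 1.0-fold lower number (0.01 log units; within the scatter) from compound 2 to compound 4, 1.4-fold (0.14 log units) apart, within the scatter of two such steps This shows that, across these two pairs, the change behaved alike on both cores and left the numbers within the scatter, but it does not show that a real effect carries over, as neither step is large enough to stand out from the scatter, and two pairs say nothing about any further core.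

The compounds shown leave open whether another group in the same place, such as a carboxylic acid, a primary amine or a longer alkoxy chain, would shift the number beyond the scatter. They also leave open whether replacing the methoxy or methyl group on the shared core would alter the outcome of this change.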